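The source may hold more compounds than are shown below. What is called first, only, known or untested is meant among the compounds shown, and "the series" means these compounds.

In a physicochemical assay for solubility, read by spectrophotometry, in phosphate buffer, with a stated time of 18 h, at pH 7.4 (a higher number here means a more soluble compound, a lower number a less soluble compound), compound 1 `CCCc1ccc(-c2nc3c(c(C)nn3-c3ccccc3)c(-c3ccccc3O)c2C#N)cc1` gives 6500 nM and compound 2 `Cc1nn(-c2ccccc2)c2nc(-c3ccc4ccccc4c3)c(C#N)c(-c3ccccc3O)c12` gives 1800 nM, the lower of the two numbers. Compound 3 `Cc1nn(-c2ccccc2)c2nc(-c3ccc(C(F)(F)F)cc3)c(C#N)c(-c3ccccc3O)c12` puts 4-(trifluoromethyl)phenyl in place of naphthalen-2-yl on an aromatic carbon. Within the data shown here, one measured step bears on this: a 3.6-fold lower number from compound 1 to compound 2 (0.56 log units; beyond the scatter), which brought in naphthalen-2-yl in place of 4-propylphenyl. Compound 3 also gives up naphthalen-2-yl for a 4-substituted phenyl, so a partial reversal of that modest step is expected, towards a higher number. The expected step is a 2.1-fold higher number from compound 2 to compound 3 (0.32 log units; beyond the scatter). For compound 3 the estimate is 3800 nM, with an expected range of 1300 nM to 10000 nM.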

Compound 3, solubility: 3500 nM
Estimate against measurement, compound 3: 1.1-fold (0.04 log units) above, within the range that was stated.
By their numbers in this assay, from the lowest: compounds 2, 3 and 1 (each within the scatter of the next, the first and the last beyond it).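

In this assay, 4-(trifluoromethyl)phenyl in place of naphthalen-2-yl gives a 1.9-fold higher number from compound 2 to compound 3 (0.29 log units; within the scatter) and trifluoromethyl in place of propyl gives a 1.9-fold lower number from compound 1 to compound 3 (0.27 log units; within the scatter) on the same phenyl group, both within the scatter. Compound 3 thus shows that this position tolerates a change of group with no readable shift, and only the wider gap between compound 1 and compound 2 exceeds the scatter. No evidence bearing on these numbers is available. On these data alone, whether an amine or a carboxylic acid in place of trifluoromethyl, or a chain longer than propyl, would move the number beyond the scatter stays open.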